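Para substituent on the triazole phenyl: chloro analogue

This account rests on a few compounds, and the source may have more. Where it says the series, first, only, none or still open, it means among the compounds named here.

Values in a functional assay on A549 cells (Homo sapiens) for cytotoxicity, read by MTT assay, with a stated time of 4 days (a higher number here means a weaker inhibitor, a lower number a stronger inhibitor), for the measured compounds:
Compound 1 `C=C1C[C@]23C[C@@]1(O)CC[C@H]2c1cc(Br)c(O)c(C)c1[C@@H]3Cn1cc(-c2ccc(OC)cc2)nn1` gives > 20000 nM, which is a limit of the assay and not a number.
Compound 2 `C=C1C[C@]23C[C@@]1(O)CC[C@H]2c1cc(Br)c(O)c(C)c1[C@@H]3Cn1cc(-c2ccc(F)cc2)nn1` gives 17900 nM.
Compound 3 `C=C1C[C@]23C[C@@]1(O)CC[C@H]2c1cc(Br)c(O)c(C)c1[C@@H]3Cn1cc(-c2ccc(C(F)(F)F)cc2)nn1` gives 9280 nM.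

Compound 3 holds the lowest of the two numbers shown; its nearest neighbour is compound 2, with a 1.9-fold lower number from compound 2 to compound 3 (0.29 log units; within the scatter), a gap within the scatter. Against compound 1 only a limit is available, (the limit of > 20000 nM in this assay, at which 1 of the 3 values shown sits), so an at least 2.1-fold lower number from compound 1 to compound 3 (0.33 log units; beyond the scatter) is a floor rather than a measured size. Likewise an at least 1.1-fold lower number from compound 1 to compound 2 (0.04 log units; that floor lies within the scatter) is only a floor and lies within the scatter.

Compound 4 `C=C1C[C@]23C[C@@]1(O)CC[C@H]2c1cc(Br)c(O)c(C)c1[C@@H]3Cn1cc(-c2ccc(Cl)cc2)nn1` is the next member, differing from compound 3 by chloro in place of trifluoromethyl on an aromatic carbon. Going by the values given here, the steps that bear on this change are those in which the substituent on that aromatic carbon was exchanged: fluoro to trifluoromethyl, and methoxy to trifluoromethyl. Among the compounds with values here, both were small, and no step involving chloro exists. The change from compound 3 to compound 4 is therefore expected to give a number of similar size, if anything somewhat higher, and a 1.4-fold higher number from compound 3 to compound 4 (0.15 log units; within the scatter) is estimated to stay within the scatter. Compound 4 is expected at 13000 nM, with a range of 6000 nM to 28000 nM in this assay.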

Compound 4, half-maximal inhibitory concentration: 10500 nM
For compound 4 the middle estimate is 1.2-fold (0.09 log units) above the measured one; low and high end bracket the measured number.
By their numbers in this assay, from the lowest: compounds 3, 4 and 2 (each within the scatter of the next). At a limit, above all of these: compound 1.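

In this assay, chloro on this aromatic carbon, para to a large group, gives a 1.1-fold higher number from compound 3 to compound 4 (0.05 log units; within the scatter) and a 1.7-fold lower number from compound 2 to compound 4 (0.23 log units; within the scatter), so chloro cannot be told apart from trifluoromethyl or fluoro at this position. Exchanging trifluoromethyl, with 4 heavy atoms, for chloro, with 1 heavy atom, therefore leaves the number unchanged within the scatter, and compound 2, compound 3 and compound 4 form one group with no readable order among them. The remaining step, an at least 1.9-fold lower number from compound 1 to compound 4 (0.27 log units; that floor lies within the scatter), is only a floor, the methoxy end of it being a limit of the assay and not a number: the limit of > 20000 nM in this assay, at which 1 of the 4 values shown sits.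

Open, on these data alone, is whether any group at this position, such as an amine, a carboxylic acid or a nitrile, would move the number in this assay beyond the scatter from this group of compounds. The compounds shown also vary only this one position, so they say nothing on how the bromo, the hydroxyl groups or the triazole of the shared core contribute to the values.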